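Chloro on the pendant phenyl: cytotoxicity notes on a small series

A few compounds are considered here, and "the series" means these few. Any claim that something is new, unique, unknown or untested is made for them only; others in the source may bear on it.

Measured compounds in a functional assay on U-87MG ATCC cells (Homo sapiens) for cytotoxicity, read by MTT assay, with a stated time of 72 h; a higher number here means a weaker inhibitor, a lower number a stronger inhibitor:
compound 1 `COc1cc2c(Oc3ccc(NC(=O)c4cc(-c5cccc(Cl)c5)nc5ccccc45)cc3F)ccnc2cc1OCCCN1CCC(C)CC1` gives 580 nM
compound 2 `COc1cc2c(Oc3ccc(NC(=O)c4cc(-c5ccccc5)nc5ccccc45)cc3F)ccnc2cc1OCCCN1CCC(C)CC1` gives 920 nM
compound 3 `COc1cc2c(Oc3ccc(NC(=O)c4cc(-c5ccccc5)nc5ccc(F)cc45)cc3F)ccnc2cc1OCCCN1CCCC1` gives 960 nM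

Compounds 1 and 2 share one core and differ in a single place: chloro in place of hydrogen on an aromatic carbon
The step this change made in this assay, a 1.6-fold lower number from compound 2 to compound 1 (0.20 log units; within the scatter), lies within the scatter of repeated measurements, so the two values cannot be told apart on this reading alone.

Compound 3 stands on a second core. The difference between the two cores is not broken down here. Its value in this assay lies within the scatter of the value of compound 2 and of the value of compound 1, so nothing separates the three measured compounds in this read-out.

Compound 4 `COc1cc2c(Oc3ccc(NC(=O)c4cc(-c5cccc(Cl)c5)nc5ccc(F)cc45)cc3F)ccnc2cc1OCCCN1CCCC1` has not yet been measured. It differs from compound 3 by: chloro in place of hydrogen on an aromatic carbon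
This is the same change as that made from compound 2 to compound 1, at the same place on the ring.

For the measured compounds named here, the expected step from compound 3 to compound 4 in this assay is a 1.5-fold lower number from compound 3 to compound 4 (0.19 log units; within the scatter), and it is set to follow the earlier one because a 1.6-fold lower number from compound 2 to compound 1 (0.20 log units; within the scatter) is the only precedent for this change. With one precedent that itself sits within the scatter, the expectation is loose. For compound 4 the estimate in this assay is 620 nM, with a range from 300 nM to 1300 nM.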

Compound 4, half-maximal inhibitory concentration: 990 nM
Estimate against measurement, compound 4: 1.6-fold (0.20 log units) below; the range from low to high includes it.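

Carried onto the second core, the change from phenyl to 3-chlorophenyl gives, in this assay, a 1.0-fold higher number from compound 3 to compound 4 (0.01 log units; within the scatter), so this step also cannot be told apart from repeated measurement. Set beside the earlier step, the new one shows no separable difference between the two cores: the same change on two cores in this assay, a 1.6-fold lower number (0.20 log units; within the scatter) from compound 2 to compound 1 and a 1.0-fold higher number (0.01 log units; within the scatter) from compound 3 to compound 4, 1.6-fold (0.21 log units) apart, within the scatter of two such steps. This agreement does not show that the chloro change carries a real effect from one core to the other, as neither step stands clear of the scatter, and two such steps establish neither transfer of an effect nor its loss.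

The compounds shown leave open whether any substituent on this phenyl ring can move the number beyond the scatter, for example methoxy, trifluoromethyl or a nitrile, or chloro placed elsewhere on the ring. Also open, going by these compounds, is whether the side chain matters on its own terms, for example with a dimethylamino group as the terminal amine or with a longer chain, and whether a step seen there would hold on both cores.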